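Adding trifluoromethyl to the phenyl of compound 1

A few compounds are considered here, and "the series" means these few. Any claim that something is new, unique, unknown or untested is made for them only; others in the source may bear on it.

compound 1 `O=C1C(Nc2ccccc2)=CC(=O)c2c1nc1n2[C@H]2OC[C@@H](O)[C@H]2OC1`: > 4000 nM (a limit)
compound 2 `O=C1C=C(N2CCC2)C(=O)c2c1nc1n2[C@H]2OC[C@@H](O)[C@H]2OC1`: > 16000 nM (a limit)

In a functional assay on MCF7 cells (Homo sapiens) for inhibition, read by sulforhodamine B assay (on this read-out lower numbers stand for stronger inhibition and higher numbers for weaker inhibition), compound 1 is known only by a limit, > 4000 nM, and not by a number. Compound 2 is also known only by a limit, > 16000 nM. For the measured compounds named here, neither compound therefore gives a firm starting value, and no measured pair shows the size of a single change.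

Compound 3 `O=C1C(Nc2ccc(C(F)(F)F)cc2)=CC(=O)c2c1nc1n2[C@H]2OC[C@@H](O)[C@H]2OC1` shares the core of compound 1, with phenyl changed to 4-(trifluoromethyl)phenyl: trifluoromethyl in place of hydrogen on an aromatic carbon. This places trifluoromethyl in place of hydrogen on an aromatic carbon, para to a large group.

Only a modest move toward stronger inhibition is expected in this assay, possibly none beyond the scatter. The expected step is an at least 1.3-fold lower number from compound 1 to compound 3 (0.12 log units; that floor lies within the scatter). For compound 3 the estimated value is 3000 nM, with an expected range from 1000 nM to 10000 nM.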

Compound 3, half-maximal inhibitory concentration: > 4000 nM
Compound 3: a limit, no number; the forecaster's own chance of this, stated with the estimate: 50%; at least 1.3-fold (0.12 log units) between middle value and limit.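

In this assay compound 3 is known only by a limit, > 4000 nM. Compound 1 is likewise known only by a limit, and the step from compound 1 to compound 3 cannot be read. The compounds shown leave open whether trifluoromethyl in place of hydrogen changes inhibition at all, and in which direction.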